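Swapping a Hydroxy-Methoxy Benzyl for a Fluoro-Methoxy Benzyl

The source may report more compounds than this note shows. Statements on the series, on what has been measured and on what is new or still open speak of the compounds shown alone.

Of the compounds shown here, three have been measured in a physicochemical assay for solubility, with a stated time of 18 h, at pH 7.4 (a lower number here means a less soluble compound, a higher number a more soluble compound), and a fourth awaits its turn. Compound 1 `COc1cccc(CNCCCNc2ccnc3cc(-c4cc(C(F)(F)F)cc(C(F)(F)F)c4)ccc23)c1O` gives 32000 nM, the highest of the three numbers. Compound 2 `COc1ccc(F)cc1CNCCCNc1ccnc2cc(CC3CCCCC3)ccc12` gives 4200 nM in this assay, and compound 3 `COc1cccc(CNCCCNc2ccnc3cc(CC4CCCCC4)ccc23)c1O` gives 4200 nM. Compound 2 and compound 3 share a core, and differ only in 5-fluoro-2-methoxyphenyl in place of 2-hydroxy-3-methoxyphenyl on a saturated chain carbon bound to an amine nitrogen; that change gave no change at the digits printed from compound 3 to compound 2 (within the scatter). The difference between the core of compound 1 and the core of compound 3 is not broken down here.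

Compound 4 `COc1ccc(F)cc1CNCCCNc1ccnc2cc(-c3cc(C(F)(F)F)cc(C(F)(F)F)c3)ccc12` is not yet measured. It stands to compound 1 as compound 2 stands to compound 3: the change is 5-fluoro-2-methoxyphenyl in place of 2-hydroxy-3-methoxyphenyl on a saturated chain carbon bound to an amine nitrogen, the same change at the same place. Within the data shown here, the only guide to its effect is the pair already measured, where it left this assay unchanged. On that basis the step from compound 1 to compound 4 is expected to be small, a 1.1-fold lower number from compound 1 to compound 4 (0.06 log units; within the scatter), with the usual uncertainty of one pair of measurements. Compound 4 is therefore estimated to give 28000 nM in this assay, most likely falling somewhere from 12000 nM to 65000 nM.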

Compound 4, solubility: 32000 nM
For compound 4 the middle estimate is 1.1-fold (0.06 log units) below the measured one, within the range that was stated.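

In this assay the swap of 2-hydroxy-3-methoxyphenyl for 5-fluoro-2-methoxyphenyl gave no change at the digits printed from compound 1 to compound 4 (within the scatter) and, on the other core, no change at the digits printed from compound 3 to compound 2 (within the scatter), so the outcome seen on one core held on the second. Among these compounds, this is only two pairs, and it does not show that the same swap would leave the number unchanged on any further core, or in any other kind of measurement. Nothing available here accounts for the lack of change in either pair.

The swap alters the ring in more than one way at once, so the compounds shown leave open what the loss of the hydroxy group and the arrival of the fluorine each do alone. They also leave open whether the result would stay the same with a carboxylic acid or an amine on that ring, or with a longer chain in place of the present one.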